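A Chloro Group Added to a Weakly Active Compound

The source may hold more compounds than are shown below. What is called first, only, known or untested is meant among the compounds shown, and "the series" means these compounds.

Compound 1 `N#Cc1c(Nc2cccc(C(F)(F)F)c2)nc(SCc2cn(Cc3ccccc3Cl)nn2)nc1-c1ccccc1` and compound 2 `Cc1ccc(Nc2nc(SCc3cn(Cc4ccccc4Cl)nn3)nc(-c3ccccc3)c2C#N)cc1` share the same core and differ only in the group carried on a nitrogen on an aromatic ring. In a functional assay on ECa-109 cells (Homo sapiens) for inhibition, read by MTT assay, with a stated time of 72 h (on this read-out higher numbers stand for weaker inhibition and lower numbers for stronger inhibition), compound 1 gives 32000 nM. For compound 2 this assay reports only a limit, > 64000 nM, so its true value is not known. Within the data shown here, the one measured step, an at least 2.0-fold higher number from compound 1 to compound 2 (0.30 log units; that floor lies within the scatter), is accordingly only a floor.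

Compound 3 `Cc1ccc(Nc2nc(SCc3cn(Cc4ccccc4Cl)nn3)nc(-c3ccc(Cl)cc3)c2C#N)cc1` differs from compound 2 by chloro in place of hydrogen on an aromatic carbon. Among the measured compounds shown here, no measured step touches this position; the only step seen, an at least 2.0-fold higher number from compound 1 to compound 2 (0.30 log units; that floor lies within the scatter), concerns a different part of the molecule and offers no guide. With compound 2 already at a limit, compound 3 is estimated at 70000 nM, in a range from 30000 nM to 160000 nM. The expected step that the limit leaves unreadable from compound 2 to compound 3 is none beyond the usual scatter, and a limit is again likely.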

Compound 3, half-maximal inhibitory concentration: 7540 nM
Beside the measured number, compound 3's estimate is 9.3-fold (0.97 log units) above it, outside the stated range (below it).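

Phenyl to 4-chlorophenyl is the first change shown on this part of the molecule, and in this assay it gives an at least 8.4-fold lower number from compound 2 to compound 3 (0.92 log units; beyond the scatter). This position therefore responds to substitution: one chlorine, para to a large group on a six-membered aromatic ring of carbon only, is enough to separate compound 3 clearly from compound 2, whereas the earlier step, on the nitrogen, could not be told from the scatter. The true size of the new step stays unknown, because compound 2 stands at a limit of the assay: the limit of > 64000 nM in this assay, at which 1 of the 3 values shown sits.

The compounds shown carry only hydrogen or chloro at this position, so it stays open whether a fluoro group, a methoxy group or an amine there would act in the same way. Equally open, from the compounds shown here alone, is whether the same change would act alike on compound 1, which carries 3-(trifluoromethyl)phenyl on the nitrogen.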